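The compounds below may be only part of what the source reports. "The series", "measured", "known", "first", "only" and "open" are said of these compounds alone.

Measured so far in an assay on HEK293 cells for activation of Kir3.1/Kir3.2 (Homo sapiens), read by thallium flux; on this read-out higher numbers stand for an effect only at larger amounts of compound and lower numbers for an effect already at smaller amounts:
compound 1 `Cc1cc(NC(=O)Cn2nnc(-c3ccccc3)n2)n(C2CCCCC2)n1` gives 96 nM
compound 2 `Cc1ccc(-c2nnn(CC(=O)Nc3cc(C)nn3C3CCCCC3)n2)cc1` gives 111 nM

Among the measured compounds shown here, on these two numbers compound 2 and compound 1 lie within the scatter of each other; the one step between them reads a 1.2-fold higher number from compound 1 to compound 2 (0.06 log units; within the scatter), methyl in place of hydrogen on an aromatic carbon, with no effect beyond the usual spread of this assay.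

Compound 3 `Cc1cc(NC(=O)Cn2nnc(-c3ccc(C(F)(F)F)cc3)n2)n(C2CCCCC2)n1` is the next point. Relative to compound 2 the change is trifluoromethyl in place of methyl on an aromatic carbon. For the measured compounds named here, no measured step replaces a methyl by a trifluoromethyl at any position of the series, so the only guidance is the step from compound 1 to compound 2, which shows the para position of this phenyl tolerating a small substituent without change in this assay. Compound 3 is therefore expected near 110 nM, with a range of 40 nM to 300 nM. Going by the values given here, the estimated step, a 1.0-fold lower number from compound 2 to compound 3 (0.00 log units; within the scatter), is expected to remain within the scatter, though the range is kept wide because only one bearing step exists.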

Compound 3, half-maximal effective concentration: 241 nM
Compound 3: the middle estimate sits 2.2-fold (0.34 log units) below what was measured; the measured number falls inside the stated range.
By their numbers in this assay, from the lowest: compounds 1 and 2 (each within the scatter of the next); then compound 3.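

In this assay, the 4-methylphenyl to 4-(trifluoromethyl)phenyl change gives a 2.2-fold higher number from compound 2 to compound 3 (0.34 log units; beyond the scatter) at the carbon para to a large group, and the comparison with hydrogen at that carbon gives a 2.5-fold higher number from compound 1 to compound 3 (0.40 log units; beyond the scatter) on the same read-out. This position therefore does not accept every small substituent alike: hydrogen and methyl lie within the scatter of each other, while trifluoromethyl stands modestly apart from both. No available measurement bears on why trifluoromethyl differs from methyl here.

Going by these compounds, whether trifluoromethyl alone stands apart remains open, and a chlorine, a methoxy group or a nitrile at this carbon would test that. Also open, on these data alone, is whether trifluoromethyl at another carbon of this ring would read the same.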